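The source may report more compounds than this note shows. Statements on the series, on what has been measured and on what is new or still open speak of the compounds shown alone.

The measured compounds:

Compound 1, `CCOc1cc(OC)c(Br)cc1C(C)=O`, gives 36000000 nM in a functional assay, read by spectrophotometry, with a stated time of 6 min; on this read-out lower numbers stand for stronger inhibition and higher numbers for weaker inhibition.
Compound 2, `CCCCOc1cc(OC)c(Br)cc1C(C)=O`, gives 34100000 nM in this assay.
Compound 3, `CCCCCCOc1cc(OC)ccc1C(C)=O`, gives 42100000 nM in this assay.

All three numbers are very high, which on this read-out means weak inhibition, and they lie within the usual scatter of one another, so no order among them can be claimed. Going by the values given here, only one pair differs in a single place: compound 1 and compound 2, where the change is ethyl in place of hydrogen on a saturated chain carbon, two bonds along the chain from an oxygen on an aromatic ring. That change produced a 1.1-fold lower number from compound 1 to compound 2 (0.02 log units; within the scatter). Compound 3 carries a different core from compound 1; the difference between the two cores is not broken down here, and their two values show only that they sit close together.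

Compound 4, `CCCCCCCCOc1cc(OC)ccc1C(C)=O`, has not been measured yet. It differs from compound 3 by ethyl in place of hydrogen on a saturated chain carbon, six bonds along the chain from an oxygen on an aromatic ring. Among the compounds with values here, this is the same kind of change as the one from compound 1 to compound 2, but not the same: there the entering ethyl sits on a saturated chain carbon two bonds along the chain from an oxygen on an aromatic ring, whereas here it sits on a saturated chain carbon six bonds along the chain from an oxygen on an aromatic ring. Within the data shown here, the expected step is a 1.1-fold lower number from compound 3 to compound 4 (0.02 log units; within the scatter), because a 1.1-fold lower number from compound 1 to compound 2 (0.02 log units; within the scatter) and that is the only guide available. Compound 4 is therefore estimated at 40000000 nM, with an expected range from 15000000 nM to 110000000 nM.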

Compound 4, half-maximal inhibitory concentration: 38300000 nM
The estimate for compound 4 lay 1.0-fold (0.02 log units) above the measured number; the range from low to high includes it.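

In this assay, ethyl in place of hydrogen on a saturated chain carbon, six bonds along the chain from an oxygen on an aromatic ring, gives a 1.1-fold lower number from compound 3 to compound 4 (0.04 log units; within the scatter), a step too small to read as a real difference. Set beside the earlier step on the other core, it shows that in these two pairs the change behaves alike, with neither step rising out of the scatter: the same change on two cores in this assay, a 1.1-fold lower number (0.02 log units; within the scatter) from compound 1 to compound 2 and a 1.1-fold lower number (0.04 log units; within the scatter) from compound 3 to compound 4, 1.0-fold (0.02 log units) apart, within the scatter of two such steps. Going by these compounds alone, this does not show that the change would carry across cores in general: there are only two pairs, the ethyl enters at a different place along the chain in each, so core and place cannot be told apart, and all the numbers stand for weak inhibition, so nothing shows whether a step that could be read would also carry over.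

Within the data shown here, whether a longer chain than the one in compound 4 would stay within the scatter remains open. So does whether a chain ending in an amine or a carboxylic acid, in place of the plain saturated end, would shift the number on either core.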